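Swapping the amide aryl group: compound 2 to compound 3

The compounds below may be only part of what the source reports. "The series", "measured", "known", "first", "only" and "open" are said of these compounds alone.

Compound 1 `CCc1cccc(NC(=O)CN2CCN(c3ccccn3)CC2)c1` gives 26.2% in an assay on cells for agonist activity at D(4) dopamine receptor (Homo sapiens), read by luminescence and beta-arrestin recruitment, with a stated time of 90 min; a higher number here means a larger maximal response, a lower number a smaller maximal response. Compound 2 `CCc1cccc(NC(=O)CN2CCN(c3ccc(Cl)cn3)CC2)c1` is reported only as "not active" (no number reported) in this assay, so no number places it on the scale and it stands as a non-responder. Compound 3 `O=C(CN1CCN(c2ccc(Cl)cn2)CC1)Nc1cncnc1` has not been measured. The change from compound 2 to compound 3 is pyrimidin-5-yl in place of 3-ethylphenyl on an amide-type nitrogen. Among the compounds with values here, no measured step of this kind exists, so no shift beyond the usual scatter is expected, and another report of no activity is plausible. For compound 3 in this assay the expected largest response is 12%, within a range of 0% to 30%.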

Compound 3, largest response reached (Emax), in percent of the reference or control that the assay uses: "not active" (no number reported)
No number was reported for compound 3; the estimate stays without a comparison.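

Compound 2 and compound 3 are both reported as not active in this assay and so give no readable step. No evidence bears on this result. The compounds shown leave open whether pyrimidin-5-yl in place of 3-ethylphenyl changes a measurable response.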